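Cyclohexyl to Benzyl on the Carbamate Nitrogen

A few compounds are considered here, and "the series" means these few. Any claim that something is new, unique, unknown or untested is made for them only; others in the source may bear on it.

Compound 1 `O=C(NC1CCCC1)Oc1ccc(C2=NCCS2)cc1`: 11000 nM in an assay on cell membranes (strain Wistar) for inhibition of Monoglyceride lipase (Rattus norvegicus), read by HPLC; a higher number here means a weaker inhibitor, a lower number a stronger inhibitor
Compound 2 `O=C(NC1CCCCC1)Oc1ccc(C2=NCCS2)cc1`: 27000 nM in this assay

Within the data shown here, compound 2 gives the higher of the two numbers measured so far; its nearest neighbour is compound 1, and the only measured step, a 2.5-fold higher number from compound 1 to compound 2 (0.39 log units; beyond the scatter), goes from the smaller to the larger non-aromatic ring on the amide-type nitrogen. Compound 3 `O=C(NCc1ccccc1)Oc1ccc(C2=NCCS2)cc1` carries benzyl in place of cyclohexyl on an amide-type nitrogen. Among the measured compounds shown here, no measured step replaces a non-aromatic ring with an aromatic one, so the single step at hand bears on this change only loosely: it shows that altering the ring on this nitrogen shifts the number modestly. Compound 3 is therefore expected to land near compound 2, with the step of a 1.4-fold lower number from compound 2 to compound 3 (0.13 log units; within the scatter) estimated to lie close to the scatter, in no clear direction. The estimate for compound 3 in this assay is 20000 nM, with a range from 7000 nM to 60000 nM.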

Compound 3, half-maximal inhibitory concentration: 42000 nM
The estimate for compound 3 lay 2.1-fold (0.32 log units) below the measured number, and the stated range covers the measured number.
By their numbers in this assay, from the lowest: compound 1; then compounds 2 and 3 (each within the scatter of the next).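

In this assay the step to an aromatic ring on the amide-type nitrogen gives a 1.6-fold higher number from compound 2 to compound 3 (0.19 log units; within the scatter) and so stays within the scatter: benzyl and cyclohexyl cannot be told apart at this position. Against cyclopentyl, the same benzyl group gives a 3.8-fold higher number from compound 1 to compound 3 (0.58 log units; beyond the scatter) and this gap lies beyond the scatter, which leaves compound 1 as the strongest inhibitor of the three, with both six-membered rings giving higher numbers. No measurement at hand accounts for these differences.

The compounds shown leave open how a smaller ring such as cyclobutyl, a longer chain such as phenethyl or a phenyl group placed directly on this nitrogen would read in this assay. They also leave open whether an amine or a carboxylic acid on the benzyl ring would move the number at all.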